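This account rests on a few compounds, and the source may have more. Where it says the series, first, only, none or still open, it means among the compounds named here.

In a functional assay on KB cells (Homo sapiens) for inhibition, read by sulforhodamine B assay (on this read-out higher numbers stand for weaker inhibition of growth and lower numbers for stronger inhibition of growth), compound 1 `Oc1ccc(-c2ccc(-c3ccc(-c4nc5c(O)cccc5[nH]4)cc3)cc2)cc1` gives 3190 nM. Compound 2 `Oc1cccc2[nH]c(-c3ccc(-c4ccc(-c5cccc(Cl)c5)cc4)cc3)nc12` gives 2280 nM, and the two values lie within the scatter of each other. Compound 3 `COc1ccc(-c2ccc(-c3ccc(-c4nc5c(O)cccc5[nH]4)cc3)cc2)cc1OC` has 3,4-dimethoxyphenyl in place of 3-chlorophenyl on an aromatic carbon, para to a large group: 3,4-dimethoxyphenyl in place of 3-chlorophenyl on an aromatic carbon. Among the compounds with values here, the only measured step at this place, a 1.4-fold lower number from compound 1 to compound 2 (0.15 log units; within the scatter), exchanged 4-hydroxyphenyl for 3-chlorophenyl, so no change beyond the scatter is expected in this assay. The expected step is a 1.1-fold higher number from compound 2 to compound 3 (0.04 log units; within the scatter). For compound 3 the estimated value is 2500 nM, with an expected range from 1000 nM to 6500 nM.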

Compound 3, concentration for 50% growth inhibition: 2710 nM
The estimate for compound 3 lay 1.1-fold (0.04 log units) below the measured number; the range from low to high includes it.
By their numbers in this assay, from the lowest: compounds 2, 3 and 1 (each within the scatter of the next).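

In this assay, the 3,4-dimethoxyphenyl group, which adds two hydrogen-bond acceptors and is larger by heavy-atom count than 3-chlorophenyl, gives no change beyond the scatter (a 1.2-fold higher number from compound 2 to compound 3 (0.08 log units; within the scatter)), and the same holds against 4-hydroxyphenyl (a 1.2-fold lower number from compound 1 to compound 3 (0.07 log units; within the scatter)). This position, para to a large group, has now tolerated three differently substituted phenyl rings with no step beyond the scatter. Nothing available explains this flatness.

From the compounds shown here alone, all three groups are substituted phenyl rings, so it remains open whether a basic amine or a carboxylic acid on that ring would shift the number. Replacing the ring with a short alkyl chain is equally untested among these compounds.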